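Putting a Sulfonyl Back Where Carboxy Failed

The source may hold more compounds than are shown below. What is called first, only, known or untested is meant among the compounds shown, and "the series" means these compounds.

Compound 1 `FC(F)(F)c1ccc(Nc2ncnc3sc(Nc4c(Cl)cccc4Cl)nc23)cc1` and compound 2 `CS(=O)(=O)c1ccc(Nc2ncnc3sc(Nc4c(Cl)cccc4Cl)nc23)cc1` share one core and differ only in the group on one aromatic carbon. In a functional assay on HEK293 cells for antagonist activity at transient receptor potential cation channel subfamily V member 1 (Rattus norvegicus), read by calcium flux (on this read-out lower numbers stand for stronger inhibition and higher numbers for weaker inhibition), compound 1 gives 3 nM, and compound 2 gives 3 nM, so there is no change at the digits printed from compound 1 to compound 2 (within the scatter). Compound 3 `O=C(O)c1ccc(Nc2ncnc3sc(Nc4c(Cl)cccc4Cl)nc23)cc1` carries a carboxy group on that carbon. In this assay compound 3 gives only > 5000 nM, a limit rather than a number (the limit of > 5000 nM in this assay, at which 1 of the 3 values shown sits). Set against the other two, compound 3 shows an at least 1600-fold higher number from compound 1 to compound 3 (3.22 log units; beyond the scatter) and an at least 1600-fold higher number from compound 2 to compound 3 (3.22 log units; beyond the scatter). Compound 4 `O=S(=O)(c1ccc(Nc2ncnc3sc(Nc4c(Cl)cccc4Cl)nc23)cc1)N1CCCC1` has not yet been measured. Its change from compound 3 is (pyrrolidin-1-yl)sulfonyl in place of carboxy on an aromatic carbon. The group that enters is again a sulfonyl, and since the step from a sulfonyl to carboxy was an at least 1600-fold higher number from compound 2 to compound 3 (3.22 log units; beyond the scatter), the step back from carboxy to a sulfonyl is expected to run the other way by a large amount, an at least 500-fold lower number from compound 3 to compound 4 (2.69 log units; beyond the scatter). Compound 4 is therefore expected to give about 10 nM in this assay, with a range from 2 nM to 100 nM.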

Compound 4, half-maximal inhibitory concentration: 0.5 nM
Compound 4: the middle estimate sits 20-fold (1.30 log units) above what was measured; measured number outside the range, below it.
By their numbers in this assay, from the lowest: compound 4; then compounds 1 and 2 (each within the scatter of the next). At a limit, above all of these: compound 3.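

In this assay, the sulfonyl group does more than recover what carboxy lost at this position on the aromatic ring, with an at least 10000-fold lower number from compound 3 to compound 4 (4.00 log units; beyond the scatter). The size of that step rests on compound 3, whose value is only a limit: the limit of > 5000 nM in this assay, at which 1 of the 4 values shown sits.

Compounds 1 and 2 could not be told apart, but the new sulfonyl group now goes beyond both: pyrrolidin-1-yl in place of methyl on the sulfur gives a 6.0-fold lower number from compound 2 to compound 4 (0.78 log units; beyond the scatter), and (pyrrolidin-1-yl)sulfonyl in place of trifluoromethyl gives a 6.0-fold lower number from compound 1 to compound 4 (0.78 log units; beyond the scatter).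

The compounds shown leave open whether the five-membered ring itself matters, or whether a piperidine, a morpholine or a plain dimethylamino group on the sulfur would serve as well. These values also do not say why the numbers move as they do.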